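Working notes: from compound 3 to compound 4

The source may hold more compounds than are shown below. What is called first, only, known or untested is meant among the compounds shown, and "the series" means these compounds.

Measured in a functional assay on PC-3 cells (Homo sapiens) for cytotoxicity, read by MTT assay, with a stated time of 72 h; on this read-out lower numbers stand for stronger inhibition and higher numbers for weaker inhibition:
- Compound 1 `O=C(N/N=C/c1cccc(Cl)c1Cl)Nc1cc2c(Nc3ccc(F)c(Cl)c3)ncnc2cc1O[C@H]1CCOC1` gives 27400 nM
- Compound 2 `O=C(N/N=C/c1ccc(O)cc1O)Nc1cc2c(Nc3ccc(F)c(Cl)c3)ncnc2cc1O[C@H]1CCOC1` gives 7540 nM
- Compound 3 `COc1cc2ncnc(Nc3ccc(F)c(Cl)c3)c2cc1NC(=O)N/N=C/c1cccc(Cl)c1Cl` gives 24400 nM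

Compound 3 sits at the high end of these numbers, level with compound 1 within the scatter, and only compound 2 is clearly lower. Compound 4 `COc1cc2ncnc(Nc3ccc(F)c(Cl)c3)c2cc1NC(=O)N/N=C/c1ccc(O)cc1` is unmeasured and differs from compound 3 thus: 4-hydroxyphenyl in place of 2,3-dichlorophenyl on a carbon with a double bond to nitrogen. Within the data shown here, the closest precedent is a 3.6-fold lower number from compound 1 to compound 2 (0.56 log units; beyond the scatter) with 2,4-dihydroxyphenyl entering, a modest step. The change a 1.1-fold lower number from compound 1 to compound 3 (0.05 log units; within the scatter) stays within the scatter, so the aryl step may carry over to the methyl partner. One pair is thin support, and the entering group differs. The expected step is a 2.4-fold lower number from compound 3 to compound 4 (0.39 log units; beyond the scatter) in the same direction, modest at most. Compound 4 is expected at 10000 nM (range 4000 nM to 25000 nM).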

Compound 4, half-maximal inhibitory concentration: 16600 nM
Compound 4: middle estimate off by 1.7-fold (0.22 log units), on the low side; measured number inside the range.
By their numbers in this assay, from the lowest: compound 2; then compounds 4, 3 and 1 (each within the scatter of the next).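

In this assay, 4-hydroxyphenyl in place of 2,3-dichlorophenyl gives a 1.5-fold lower number from compound 3 to compound 4 (0.17 log units; within the scatter), so on the methyl partner this change at the carbon with a double bond to nitrogen stays within the scatter. The step beyond the scatter, a 3.6-fold lower number from compound 1 to compound 2 (0.56 log units; beyond the scatter), therefore does not extend to this different entering group on the methyl partner. Nothing available explains the difference between these two steps.

Open, as far as these compounds go, is whether 2,4-dihydroxyphenyl keeps its step on the methyl partner, and how 4-hydroxyphenyl reads on the oxolan-3-yl partner. Also open, from the compounds shown here alone, is how an aminophenyl or carboxyphenyl group would read at this position.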